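Chloro to Methoxy on the Second Aryl Ring

The source may report more compounds than this note shows. Statements on the series, on what has been measured and on what is new or still open speak of the compounds shown alone.

Compound 1 `O=C(/C=C\Nc1ccc(F)cc1)c1cn(-c2ccccc2)nc1-c1ccc(Cl)cc1` sits at a limit of the assay, > 50000 nM. Compound 2 `O=C(/C=C\Nc1ccc(Cl)cc1)c1cn(-c2ccccc2)nc1-c1ccc(Cl)cc1` gives 3670 nM. Compound 3 `COc1ccc(N/C=C\C(=O)c2cn(-c3ccccc3)nc2-c2ccc(Cl)cc2)cc1` gives 6460 nM.

In a functional assay on A549 cells (Homo sapiens) for antiproliferative activity, read by MTT assay, with a stated time of 48 h (on this read-out lower numbers stand for stronger inhibition and higher numbers for weaker inhibition), compound 3 stands highest of the two numbers shown, with compound 2 nearest; the gap a 1.8-fold higher number from compound 2 to compound 3 (0.25 log units; within the scatter) lies within the scatter. For compound 1 only the limit is known (the limit of > 50000 nM in this assay, at which 1 of the 3 values shown sits).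

Compound 4 `COc1ccc(N/C=C\C(=O)c2cn(-c3ccccc3)nc2-c2ccc(OC)cc2)cc1` differs from compound 3 by methoxy in place of chloro on an aromatic carbon. Within the data shown here, the only measured step of the same kind, on the other ring, is a 1.8-fold higher number from compound 2 to compound 3 (0.25 log units; within the scatter), and it stayed within the scatter; the steps of an at least 13-fold lower number from compound 1 to compound 2 (1.13 log units; beyond the scatter) and an at least 7.7-fold lower number from compound 1 to compound 3 (0.88 log units; beyond the scatter) concern fluoro and bear less directly. The expected step of a 1.2-fold higher number from compound 3 to compound 4 (0.09 log units; within the scatter) is therefore small. Compound 4 is estimated at 8000 nM, between 3000 nM and 25000 nM.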

Compound 4, half-maximal inhibitory concentration: 6780 nM
For compound 4 the middle estimate is 1.2-fold (0.07 log units) above the measured one; the measured number falls inside the stated range.
By their numbers in this assay, from the lowest: compounds 2, 3 and 4 (each within the scatter of the next). At a limit, above all of these: compound 1.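

In this assay, the change from 4-chlorophenyl to 4-methoxyphenyl gives a 1.0-fold higher number from compound 3 to compound 4 (0.02 log units; within the scatter), so the two groups cannot be told apart at this position. Methoxy in place of chloro has now been read on two different rings, and neither this step nor a 1.8-fold higher number from compound 2 to compound 3 (0.25 log units; within the scatter) goes beyond the scatter. Nothing shown gives a cause for this result.

From the compounds shown here alone, what fluoro, an amine or a carboxylic acid would give at this position stays open. So does whether a longer chain in place of methoxy would stay within the scatter.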